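Working notes: ring amine substituent change, compound 1 to compound 4

The source may hold more compounds than are shown below. What is called first, only, known or untested is meant among the compounds shown, and "the series" means these compounds.

Measured so far:
- compound 1 `CC(=O)N1CCC(c2cc3c(-c4ccc(=O)n(C(C)C)c4)ccnc3[nH]2)CC1`: 2.8 uL/min
- compound 2 `CC(C)n1nc(-c2ccnc3[nH]c(C4CCN(CC(=O)N(C)C)CC4)cc23)ccc1=O`: 3.1 uL/min
- compound 3 `CC(C)Cn1cc(-c2ccnc3[nH]c(C4CCN(CC(=O)N(C)C)CC4)cc23)ccc1=O`: 6.6 uL/min

All three numbers come from an ADME assay on cells (Hepatocyte, Rattus norvegicus) for metabolic stability; on this read-out lower numbers stand for slow clearance and higher numbers for fast clearance. In this assay compound 1 gives 2.8 uL/min, the lowest of the three numbers. Compound 2 is within the scatter of compound 1; compound 3 stands a little beyond the scatter above compound 1, so the spread across the set is modest and the three compounds share one core with different groups on the amine nitrogen in a ring.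

Going by the values given here, the next compound, compound 4 `CC(C)n1cc(-c2ccnc3[nH]c(C4CCN(Cc5cccs5)CC4)cc23)ccc1=O`, keeps the core of compound 1 and changes only that group: (thiophen-2-yl)methyl in place of acetyl on an amine nitrogen in a ring. Among the compounds with values here, no measured pair carries this change, so the size of the step has to be judged from the change itself and from where compound 1 sits.

For compound 4 the expectation is a step upward in this assay beyond the scatter, a 4.3-fold higher number from compound 1 to compound 4 (0.63 log units; beyond the scatter), because compound 1 already gives the lowest number with 2.8 uL/min and a change this large on the amine nitrogen in a ring is unlikely to leave the number unchanged. The estimate for compound 4 is 12 uL/min, with a range from 5 uL/min to 30 uL/min.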

Compound 4, intrinsic clearance in a liver preparation (reported as CLH), per the amount of preparation that the assay uses: 43 uL/min
Beside the measured number, compound 4's estimate is 3.6-fold (0.55 log units) below it, and the stated range ends below it.
By their numbers in this assay, from the lowest: compounds 1 and 2 (each within the scatter of the next); then compound 3; then compound 4.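

In this assay, placing (thiophen-2-yl)methyl in place of acetyl on an amine nitrogen in a ring gives a 15-fold higher number from compound 1 to compound 4 (1.19 log units; beyond the scatter) and counts as a large step. Going by these compounds alone, this is the first step that can be read at a single place, and it shows that the group on this nitrogen can by itself move the number far more than the modest spread among the earlier compounds suggested. No measurement at hand accounts for the size of this step.

On these data alone, this one pair cannot separate what the departure of acetyl contributes from what the arrival of (thiophen-2-yl)methyl contributes, so it remains open whether other groups on this nitrogen would behave like either one. A benzyl group or a plain methyl group on the same nitrogen of the core of compound 1 would help to separate the ring from the carbonyl, and a methanesulfonyl group would show whether the low number of compound 1 is tied to acetyl alone.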